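Methoxyphenyl for methylthiophenyl in a cytotoxic series

A few compounds are considered here, and "the series" means these few. Any claim that something is new, unique, unknown or untested is made for them only; others in the source may bear on it.

In a functional assay on MCF7 cells (Homo sapiens) for cytotoxicity (on this read-out higher numbers stand for weaker inhibition and lower numbers for stronger inhibition), compound 1 (`C=C/C=C\[C@H](C)[C@H](OC(N)=O)[C@@H](C)[C@H](O)[C@@H](C)C/C(C)=C\[C@H](C)[C@@H](O)[C@@H](C)/C=C\CCc1ccc(C)c(F)c1`) gives 1000 nM, compound 2 (`C=C/C=C\[C@H](C)[C@H](OC(N)=O)[C@@H](C)[C@H](O)[C@@H](C)C/C(C)=C\[C@H](C)[C@@H](O)[C@@H](C)/C=C\CCc1cccc(Cl)c1`) gives 400 nM and compound 3 (`C=C/C=C\[C@H](C)[C@H](OC(N)=O)[C@@H](C)[C@H](O)[C@@H](C)C/C(C)=C\[C@H](C)[C@@H](O)[C@@H](C)/C=C\CCc1sccc1C`) gives 370 nM. Compound 3 shares the low end of these numbers: a 1.1-fold lower number from compound 2 to compound 3 (0.03 log units; within the scatter). The other measured steps are modest: a 2.5-fold lower number from compound 1 to compound 2 (0.40 log units; beyond the scatter) and a 2.7-fold lower number from compound 1 to compound 3 (0.43 log units; beyond the scatter).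

Compound 4 (`C=C/C=C\[C@H](C)[C@H](OC(N)=O)[C@@H](C)[C@H](O)[C@@H](C)C/C(C)=C\[C@H](C)[C@@H](O)[C@@H](C)/C=C\CCc1cccc(OC)c1`) carries 3-methoxyphenyl in place of 3-methylthiophen-2-yl on a saturated chain carbon, two bonds along the chain from a double-bonded chain carbon. All three measured steps change this same place, and none is large. The nearest measured group by name is the 3-chlorophenyl of compound 2, at 400 nM.

No change beyond the scatter is expected: a 1.3-fold higher number from compound 3 to compound 4 (0.11 log units; within the scatter). For compound 4 the estimate is 480 nM, with an expected range of 200 nM to 1100 nM.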

Compound 4, half-maximal inhibitory concentration: 330 nM
Compound 4: middle estimate off by 1.5-fold (0.16 log units), on the high side, and the stated range covers the measured number.
By their numbers in this assay, from the lowest: compounds 4, 3 and 2 (each within the scatter of the next); then compound 1.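

At this position in this assay, a six-membered carbon ring carrying methoxy is interchangeable with the thiophene (a 1.1-fold lower number from compound 3 to compound 4 (0.05 log units; within the scatter)), and methoxy in place of chloro on the aromatic carbon likewise gives no change beyond the scatter (a 1.2-fold lower number from compound 2 to compound 4 (0.08 log units; within the scatter)). The 3-fluoro-4-methylphenyl group remains the only one set apart (a 3.0-fold lower number from compound 1 to compound 4 (0.48 log units; beyond the scatter)), so an oxygen-bearing group fits the tolerance seen so far.

Going by these compounds, whether an amine or a carboxylic acid in place of methoxy would stay in this range remains open, as does which feature of 3-fluoro-4-methylphenyl raises the number. No evidence on the cause of these steps is available.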